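A few compounds are considered here, and "the series" means these few. Any claim that something is new, unique, unknown or untested is made for them only; others in the source may bear on it.

Compound 2 `COc1cc(Cl)cc(-c2nn(-c3cccc(NC(=O)Nc4ccc(Cl)c(C(F)(F)F)c4)c3)cc2-c2ccncc2)c1` is, in a functional assay on NCI-H322M cells (Homo sapiens) for inhibition, read by sulforhodamine B assay, with a stated time of 48 h, tested at 1 uM (a higher number here means a weaker effect of the compound at the concentration tested, a lower number a stronger effect), the lower of the two numbers measured: compound 2 gives 89%, and its nearest neighbour, compound 1 `O=C(Nc1cccc(-n2cc(-c3ccncc3)c(-c3cc(O)cc(Cl)c3)n2)c1)Nc1ccc(Cl)c(C(F)(F)F)c1`, gives 93%. Within the data shown here, the only measured step, a number 4 percentage points lower from compound 1 to compound 2 (within the scatter), lies within the scatter, so the two compounds are not distinguished by this assay.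

The next compound, compound 3 `COc1cc(Cl)cc(-c2nn(-c3cccc(NC(=O)c4cccc(C(F)(F)F)c4)c3)cc2-c2ccncc2)c1`, has not yet been measured. It differs from compound 2 in one place: 3-(trifluoromethyl)phenyl in place of (4-chloro-3-(trifluoromethyl)phenyl)amino on a carbonyl carbon. Among the measured compounds shown here, no measured step bears on this kind of change; the single step available concerns a methyl in place of hydrogen on an oxygen on an aromatic ring, not the group on the carbonyl carbon. The expectation for compound 3 therefore rests on the two measured numbers alone, which are both close to the upper end of the scale.

On that basis compound 3 is expected to give 88% in this assay, with a range from 70% to 102%, which means an expected step of a number 1 percentage points lower from compound 2 to compound 3 (within the scatter), not beyond the scatter.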

Compound 3, a percentage reported as activity, at one concentration (the size of the read-out at that concentration, not a potency): 90%
Compound 3: the middle estimate sits 2 percentage points below what was measured; low and high end bracket the measured number.
By their numbers in this assay, from the lowest: compounds 2, 3 and 1 (each within the scatter of the next).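

Exchanging (4-chloro-3-(trifluoromethyl)phenyl)amino for 3-(trifluoromethyl)phenyl on the carbonyl carbon gives, in this assay, a number 1 percentage points higher from compound 2 to compound 3 (within the scatter), so this read-out does not separate the two groups. The earlier step touched only the oxygen on an aromatic ring, whereas this one changes the group on a carbonyl carbon whose other neighbour is an amide-type nitrogen: the group that leaves carries a hydrogen-bond donor and a chlorine, the group that enters carries neither, and the result still stays within the scatter. No independent information is available that would explain this result.

The compounds shown leave open whether any group on this carbonyl carbon can move the read-out beyond the scatter, since compound 1, compound 2 and compound 3 all lie close together at the single concentration tested. Going by these compounds, how a morpholine or a carboxylic acid in that place would read in this assay remains open, as does the separate contribution of the amino nitrogen and of the chlorine, which left together in this one step.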